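Notes on the step from compound 3 to compound 4

A few compounds are considered here, and "the series" means these few. Any claim that something is new, unique, unknown or untested is made for them only; others in the source may bear on it.

Measured in a functional assay on SiHa cells (Homo sapiens) for inhibition, read by sulforhodamine B assay; on this read-out higher numbers stand for weaker inhibition of growth and lower numbers for stronger inhibition of growth:
- compound 1 `Oc1ccc(-c2ccc(-c3ccc(-c4nc5ccccc5[nH]4)cc3)cc2)cc1` gives 33300 nM
- compound 2 `Oc1cccc2[nH]c(-c3ccc(-c4ccc(-c5ccc(F)cc5)cc4)cc3)nc12` gives 9100 nM
- compound 3 `Oc1cccc2[nH]c(-c3ccc(-c4ccc(-c5ccc(C(F)(F)F)cc5)cc4)cc3)nc12` gives 3720 nM

Compound 3 stands lowest of these three numbers. Compound 4 `Oc1ccc(-c2ccc(-c3ccc(-c4nc5c(O)cccc5[nH]4)cc3)cc2)cc1` carries hydroxy in place of trifluoromethyl on an aromatic carbon on an aromatic carbon. Within the data shown here, the one measured step is a 2.4-fold lower number from compound 2 to compound 3 (0.39 log units; beyond the scatter) and is modest, but it shows only that the group at this place can shift the number. Compound 1 also carries 4-hydroxyphenyl and gives 33300 nM on a different core. A higher number is therefore expected, by a moderate step. The estimate means a 2.7-fold higher number from compound 3 to compound 4 (0.43 log units; beyond the scatter) in this read-out. For compound 4 the expected value is 10000 nM with an estimated range from 3500 nM to 30000 nM in this assay when measured.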

Compound 4, concentration for 50% growth inhibition: 2410 nM
The estimate for compound 4 lay 4.1-fold (0.62 log units) above the measured number; measured number below the stated range.
By their numbers in this assay, from the lowest: compounds 4 and 3 (each within the scatter of the next); then compound 2; then compound 1.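

In this assay, hydroxy in place of trifluoromethyl gives a 1.5-fold lower number from compound 3 to compound 4 (0.19 log units; within the scatter) and the two groups cannot be told apart at this place. Against fluoro, the same hydroxy gives a 3.8-fold lower number from compound 2 to compound 4 (0.58 log units; beyond the scatter) and so matches the gain that trifluoromethyl showed over fluoro. At a second place, on the shared core, hydroxy in place of hydrogen gives a 14-fold lower number from compound 1 to compound 4 (1.14 log units; beyond the scatter) and this is the largest step among these compounds.

On these data alone, whether an amine or a carboxylic acid at the 4-hydroxyphenyl position would hold the number stays open. Nothing available explains why hydroxy and trifluoromethyl read alike here.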